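Series notes: (4-aminobenzyl)amino analogue of compound 1

This account rests on a few compounds, and the source may have more. Where it says the series, first, only, none or still open, it means among the compounds named here.

Measured in a functional assay on HEK293 cells for inhibition of Voltage-dependent T-type calcium channel subunit alpha-1G (Homo sapiens); on this read-out lower numbers stand for stronger inhibition and higher numbers for weaker inhibition:
compound 1 `O=C(CC1c2ccccc2N=C(N2CCCCC2)N1c1ccccc1)NCc1ccccc1`: 900 nM
compound 2 `O=C(CC1c2ccccc2N=C(N2CCOCC2)N1c1ccccc1)NCc1ccccc1`: 21600 nM

Going by the values given here, compound 1 has the lowest of the two numbers; the only measured step, a 24-fold higher number from compound 1 to compound 2 (1.38 log units; beyond the scatter), lies beyond the scatter. Compound 3 `Nc1ccc(CNC(=O)CC2c3ccccc3N=C(N3CCCCC3)N2c2ccccc2)cc1` differs from compound 1 by amino in place of hydrogen on an aromatic carbon. Among the compounds with values here, the one measured step concerns the group on the carbon with a double bond to nitrogen, not the benzylamino end, so it does not bear on this change. No step beyond the scatter in this assay is therefore expected in either direction; the expected step is no change at the digits printed from compound 1 to compound 3 (within the scatter). Compound 3 is estimated at 900 nM, range 300 nM to 2700 nM.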

Compound 3, half-maximal inhibitory concentration: 14400 nM
For compound 3 the middle estimate is 16-fold (1.20 log units) below the measured one, outside the stated range (above it).
By their numbers in this assay, from the lowest: compound 1; then compounds 3 and 2 (each within the scatter of the next).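

In this assay, the benzylamino end of the series proves sensitive to substitution: amino in place of hydrogen on an aromatic carbon gives a 16-fold higher number from compound 1 to compound 3 (1.20 log units; beyond the scatter). A change at this end, and not only at the group on the carbon with a double bond to nitrogen, can therefore move the number beyond the scatter. No measured evidence bears on the cause of this step. Still open, on these data alone, is whether this step is specific to amino or follows any group at this place. Methoxy, fluorine or acetamido here would separate these readings, and amino on another carbon of that ring remains open too.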